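A few compounds are considered here, and "the series" means these few. Any claim that something is new, unique, unknown or untested is made for them only; others in the source may bear on it.

Three analogues built on one shared core have been measured in a functional assay on MCF7 cells (Homo sapiens) for inhibition, read by sulforhodamine B assay; on this read-out higher numbers stand for weaker inhibition and lower numbers for stronger inhibition: compound 1 `O=C1C=C(Nc2ccc(I)cc2)C(=O)c2c1nc1n2[C@H]2OC[C@@H](O)[C@H]2OC1` gives 2230 nM, compound 2 `Cc1ccc(NC2=CC(=O)c3nc4n(c3C2=O)[C@H]2OC[C@@H](O)[C@H]2OC4)cc1C` gives 2080 nM, and compound 3 `O=C1C(Nc2cccc(Cl)c2)=CC(=O)c2c1nc1n2[C@H]2OC[C@@H](O)[C@H]2OC1` gives 2970 nM. On these numbers compound 3 carries the highest value, though its gaps to compound 1 and to compound 2 both lie within the scatter. Compound 4 `O=C1C(N2CCCCC2)=CC(=O)c2c1nc1n2[C@H]2OC[C@@H](O)[C@H]2OC1` awaits measurement; it differs from compound 3 by piperidin-1-yl in place of (3-chlorophenyl)amino on a double-bonded ring carbon. Among the measured compounds shown here, the only measured step, a 1.1-fold lower number from compound 1 to compound 2 (0.03 log units; within the scatter), exchanges one aryl group for another on an amine nitrogen and bears only loosely on swapping the entire (3-chlorophenyl)amino group for piperidin-1-yl. For the measured compounds named here, since no measured step leaves the scatter, a step of a 1.1-fold higher number from compound 3 to compound 4 (0.03 log units; within the scatter) is expected. Compound 4 is estimated at 3200 nM, with a range from 1200 nM to 9000 nM.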

Compound 4, half-maximal inhibitory concentration: > 8000 nM
Compound 4 ended at the assay's limit; the forecaster's own chance of this, stated with the estimate: 10%; middle value at least 2.5-fold (0.39 log units) from the limit.
By their numbers in this assay, from the lowest: compounds 2, 1 and 3 (each within the scatter of the next). At a limit, above all of these: compound 4.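

Swapping (3-chlorophenyl)amino for piperidin-1-yl on the double-bonded ring carbon gave, in this assay, an at least 2.6-fold higher number from compound 3 to compound 4 (0.43 log units; beyond the scatter). Compounds 1, 2 and 3, all carrying an arylamino group, had shown no step beyond the scatter, so this is the first sign that the group at this place can matter. The value of compound 4 is a limit, not a number: the limit of > 8000 nM in this assay, at which 1 of the 4 values shown sits.

The change removes the aromatic ring and the amine hydrogen at once, and the compounds shown do not separate the two. Cyclohexylamino, which keeps that hydrogen without the aromatic ring, and methyl(phenyl)amino, which keeps the ring without the hydrogen, would part them.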